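Working notes: from compound 2 to compound 4

This account rests on a few compounds, and the source may have more. Where it says the series, first, only, none or still open, it means among the compounds named here.

Measured so far in an ADME assay on microsomes from liver (Mus musculus) for metabolic stability, using NADPH, with a stated time of 10 min (a higher number here means that more of the compound is left, a lower number that less of the compound is left), for three compounds
- compound 1 `CN(C[C@H]1Cc2c(cccc2N2C[C@H]3CNC[C@H]3C2)CN1)[C@H]1CCCc2cccnc21` at 54.7%
- compound 2 `CN(C)[C@@H]1CCN(c2cccc3c2C[C@H](CN(C)[C@H]2CCCc4cccnc42)NC3)C1` at 28.2%
- compound 3 `CN1CCN(Nc2cccc3c2C[C@@H](CN(C)[C@H]2CCCc4cccnc42)NC3)CC1` at 85.8%

Of these three numbers, compound 2 at 28.2% is the lowest, with compound 1 nearest and compound 3 furthest above it, both gaps beyond the scatter.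

Not yet measured is compound 4 `CN1C[C@@H]2CN(c3cccc4c3C[C@H](CN(C)[C@H]3CCCc5cccnc53)NC4)C[C@@H]2C1` and the rest of its structure matches compound 2. The structural change is a group of 9 heavy atoms (7 carbon, 2 nitrogen; 2 five-membered non-aromatic rings with 1 hetero atom each) in place of a group of 8 heavy atoms (6 carbon, 2 nitrogen; one five-membered non-aromatic ring with 1 hetero atom), on an aromatic carbon and it is the only one.

Among the measured compounds shown here, the one measured step that bears on this is a number 26.5 percentage points lower from compound 1 to compound 2 (beyond the scatter) and it is modest but beyond the scatter. Compound 1 also carries 2 five-membered non-aromatic rings with 1 hetero atom each in that place, so compound 2 to compound 4 reverses that ring count. The two groups are not identical, so only part of that gap is expected back. For the measured compounds named here, no measured step links compound 3 to this change.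

An upward move is expected, and the estimated step is a number 15.8 percentage points higher from compound 2 to compound 4 (beyond the scatter) in this assay on this single precedent. For compound 4 the estimated value is 44% with an expected range from 26% to 64% until a measurement is available.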

Compound 4, percent of the compound remaining: 32.9%
Compound 4: the middle estimate sits 11.1 percentage points above what was measured, and the stated range covers the measured number.
By their numbers in this assay, from the lowest: compounds 2 and 4 (each within the scatter of the next); then compound 1; then compound 3.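

In this assay, the group with 2 five-membered non-aromatic rings in place of 3-(dimethylamino)pyrrolidin-1-yl on this aromatic carbon gives a number 4.7 percentage points higher from compound 2 to compound 4 (within the scatter) and so the ring count at this place does not by itself separate the two compounds. The step that stands out is the methyl in place of hydrogen on the amine nitrogen in a ring, which gives a number 21.8 percentage points lower from compound 1 to compound 4 (beyond the scatter). The earlier gap between compound 1 and compound 2 therefore goes with that nitrogen substituent in this pair rather than with the ring count alone. Nothing at hand gives a reason for either step.

On these data alone, whether an ethyl or an acetyl on that ring nitrogen would read close to compound 1 or close to compound 4 stays open, as one methyl-for-hydrogen step cannot show how the read-out follows the substituent there. Also open, as far as these compounds go, is whether a morpholine at the same aromatic carbon, with the rest of the structure of compound 2 unchanged, would read apart from these two groups.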